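The source may report more compounds than this note shows. Statements on the series, on what has been measured and on what is new or still open speak of the compounds shown alone.

Compound 1, `CCC(C)(O)CC(=O)O[C@H](CC=C(C)C)C1=CC(=O)c2c(O)ccc(O)c2C1=O`, carries a shared core joined through an ester to a short side chain that ends in the 1-hydroxy-1-methylpropyl group. Among the compounds with values here, in a functional assay on HeLa cells (Homo sapiens) for cytotoxicity, read by MTT assay (on this read-out lower numbers stand for stronger inhibition and higher numbers for weaker inhibition), compound 1 gives 25200 nM, the lowest number among the three compounds measured so far. Compound 2, `CCCC(CC(=O)O[C@H](CC=C(C)C)C1=CC(=O)c2c(O)ccc(O)c2C1=O)OC(C)=O`, replaces that group with a 1-acetoxybutyl group, and in this assay compound 2 gives 51200 nM, a step of a 2.0-fold higher number from compound 1 to compound 2 (0.31 log units; beyond the scatter). Compound 3, `CCCCC(CC(=O)O[C@H](CC=C(C)C)C1=CC(=O)c2c(O)ccc(O)c2C1=O)OC(C)=O`, carries a 1-acetoxypentyl group instead, and in this assay compound 3 gives 73500 nM, a step of a 2.9-fold higher number from compound 1 to compound 3 (0.46 log units; beyond the scatter); between the two acetoxy compounds the step is a 1.4-fold higher number from compound 2 to compound 3 (0.16 log units; within the scatter).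

Compound 4, `CC(C)=CC[C@@H](OC(=O)CC(O)c1ccccc1)C1=CC(=O)c2c(O)ccc(O)c2C1=O`, is the next step from compound 1. The change is hydroxy(phenyl)methyl in place of 1-hydroxy-1-methylpropyl on a saturated chain carbon bound to a carbonyl carbon. Both measured steps from compound 1 swapped a hydroxyl-bearing group for an acetoxy-bearing chain and gave modestly higher numbers. Within the data shown here, compound 4 keeps a free hydroxyl and adds an aromatic ring, a change no measured pair mirrors, so the expectation is for a step not far beyond the scatter, leaning toward a slightly higher number, with wide uncertainty. For compound 4 in this assay the estimate is 32000 nM, with a range of 12000 nM to 85000 nM, meaning an expected step of a 1.3-fold higher number from compound 1 to compound 4 (0.10 log units; within the scatter).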

Compound 4, half-maximal inhibitory concentration: 44500 nM
Compound 4: middle estimate off by 1.4-fold (0.14 log units), on the low side, within the range that was stated.
By their numbers in this assay, from the lowest: compounds 1, 4, 2 and 3 (each within the scatter of the next, the first and the last beyond it).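

In this assay, the step to the new group reads a 1.8-fold higher number from compound 1 to compound 4 (0.25 log units; within the scatter), so at this place, on a saturated chain carbon bound to a carbonyl carbon, a six-membered aromatic ring of carbon only can enter alongside a hydroxyl without a step that clears the usual scatter. Set against the two acetoxy chains, the readings are a 1.7-fold lower number from compound 3 to compound 4 (0.22 log units; within the scatter) and a 1.2-fold lower number from compound 2 to compound 4 (0.06 log units; within the scatter), so compound 4 cannot be told apart from any of the other three compounds, even though the step between compound 1 and compound 3 lies beyond the scatter. The data shown offer no independent measurement that could explain these small steps.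

Still open, going by these compounds, is how much of the gap between compound 1 and the acetoxy compounds belongs to the acetoxy group itself, a question that acetoxy(phenyl)methyl at this place would put directly against compound 4. Also open, on these data alone, is whether a group of a different kind here, such as an amine or a carboxylic acid, would produce a step that clearly exceeds the scatter in this assay.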